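From one aryl carbamate to the next

The source may hold more compounds than are shown below. What is called first, only, known or untested is meant among the compounds shown, and "the series" means these compounds.

For the measured compounds named here, compound 1 `COc1ccc2c(c1)C(n1ccccc1=O)=CC(C)(C)O2` and compound 2 `CC1(C)C=C(n2ccccc2=O)c2cc(OC(=O)Nc3ccccc3F)ccc2O1` are the two measured members of this small set. In a functional assay (aorta) with Rattus norvegicus as the target (a higher number here means a more potent compound, by a factor of ten per unit of this negative logarithm, a lower number a less potent compound), compound 1 gives 6.55, and compound 2 gives 5.38, which is the lower of the two numbers. Going by the values given here, the single measured step, a number 1.17 log units lower from compound 1 to compound 2 (beyond the scatter), separates them. Compound 3 `CC1(C)C=C(n2ccccc2=O)c2cc(OC(=O)Nc3ccc(C(F)(F)F)cc3)ccc2O1` is the new member, not yet measured. Its structural difference from compound 2 is 4-(trifluoromethyl)phenyl in place of 2-fluorophenyl on an amide-type nitrogen. Among the compounds with values here, no measured step concerns a change of this kind: the only step known exchanges the group on an oxygen on an aromatic ring and says nothing about the aromatic ring on the amide-type nitrogen, so it offers no direct guide. With nothing to push the number in either direction, the step of a number 0.02 log units higher from compound 2 to compound 3 (within the scatter) is expected to stay within the scatter of this assay. Compound 3 is therefore estimated at 5.4, with a range from 4.9 to 5.9. That estimate is anchored on compound 2 because its value 5.38 is the closest measured point to the new compound.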

Compound 3, logarithm of the reciprocal of the active concentration, log(1/C): 5.1
For compound 3 the middle estimate is 0.30 log units above the measured one; the measured number falls inside the stated range.
By their numbers in this assay, from the lowest: compounds 3 and 2 (each within the scatter of the next); then compound 1.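

In this assay, for the compounds shown here, the step of a number 0.28 log units lower from compound 2 to compound 3 (within the scatter) is the first reading of a change to the aromatic ring on the amide-type nitrogen, whereas the earlier step concerned only the group on the oxygen. It shows that 2-fluorophenyl and 4-(trifluoromethyl)phenyl on this nitrogen cannot be told apart in this assay, even though the entering group has 10 heavy atoms and the leaving group 7. Going by these compounds alone, the large step from the methyl ether to the carbamate therefore remains the only change in this small set that lies beyond the scatter, and this pair adds no second one. Nothing available here explains why this exchange leaves the number within the scatter.

On these data alone, the two aryl groups compared both carry fluorine, so it remains open how the number would respond to an unsubstituted phenyl ring, or to a phenyl ring bearing a methoxy group or an amine. As far as these compounds go, it is equally open whether a group without an aromatic ring on this nitrogen, such as cyclohexyl or a longer alkyl chain, would stay within the scatter of compound 2 or fall clearly away from it.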